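One Halogen Swap, Two Cores, One Cell Assay

The source may report more compounds than this note shows. Statements on the series, on what has been measured and on what is new or still open speak of the compounds shown alone.

Compound 1 `COc1ccc(C(/C=C/c2ccc(Cl)cc2)=N/O)cc1` and compound 2 `COc1ccc(C(/C=C/c2ccc(Br)cc2)=N/O)cc1` share a core and differ in a single place: bromo in place of chloro on an aromatic carbon. In an ADME assay on cells (Mus musculus, strain Balb/c) for cytotoxicity, read by MTT assay, with a stated time of 48 h (a higher number here means that more compound is tolerated, a lower number that less compound is tolerated), compound 1 gives 291000 nM, while compound 2 gives 737000 nM, so that a 2.5-fold higher number from compound 1 to compound 2 (0.40 log units; beyond the scatter). Compound 3 `O/N=C(\C=C\c1cccs1)c1ccc(Cl)cc1` is built on a different core; the difference between the two cores is not broken down here. In this assay compound 3 gives 11800 nM, the lowest of the three numbers. Compound 4 `O/N=C(\C=C\c1cccs1)c1ccc(Br)cc1` arises from compound 3 by the same change, at the same place: bromo in place of chloro on an aromatic carbon. Because the earlier step was a 2.5-fold higher number from compound 1 to compound 2 (0.40 log units; beyond the scatter), a step of similar size is expected here, namely a 2.1-fold higher number from compound 3 to compound 4 (0.33 log units; beyond the scatter). Compound 4 is therefore expected to give about 25000 nM, most likely between 10000 nM and 70000 nM.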

Compound 4, half-maximal cytotoxic concentration: 15400 nM
Estimate against measurement, compound 4: 1.6-fold (0.21 log units) above; low and high end bracket the measured number.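

In this assay, going by these compounds alone, the swap of chloro for bromo gives a 1.3-fold higher number from compound 3 to compound 4 (0.12 log units; within the scatter) and so no step that can be told apart from repeat measurement on this core. This does not show that the swap has the same size on every core, since only two pairs are shown, and it gives no reason for the size of either step. Set side by side, the two steps show no difference in how the change carries from one core to the other: the same change on two cores in this assay, a 2.5-fold higher number (0.40 log units; beyond the scatter) from compound 1 to compound 2 and a 1.3-fold higher number (0.12 log units; within the scatter) from compound 3 to compound 4, 1.9-fold (0.29 log units) apart, within the scatter of two such steps

The compounds shown leave open what other groups at this place would give, such as fluoro, an amine or a carboxylic acid. Also open, from the compounds shown here alone, is how the same swap behaves on a third core.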